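The source may hold more compounds than are shown below. What is called first, only, known or untested is meant among the compounds shown, and "the series" means these compounds.

The measured compounds:

compound 1, `O=P(O)(O)Oc1cc(OP(=O)(O)O)cc(OP(=O)(O)O)c1`, gives 16000 nM in an assay for inhibition of inositol polyphosphate-5-phosphatase A (Homo sapiens), read by malachite green, with a stated time of 10 min; on this read-out higher numbers stand for weaker inhibition and lower numbers for stronger inhibition;
compound 2, `O=P(O)(O)Oc1cc(OP(=O)(O)O)c(OP(=O)(O)O)c(OP(=O)(O)O)c1`, gives 78000 nM in this assay.

Of these two numbers, compound 2 holds the higher one, and the gap to compound 1 lies beyond the scatter, so compound 2 is the weaker inhibitor of the pair. Compound 3, `O=P(O)(O)Oc1cccc(OP(=O)(O)O)c1OP(=O)(O)O`, is reached from compound 2 by a hydrogen atom in place of a group of 5 heavy atoms (4 oxygen, 1 phosphorus; no ring), on an aromatic carbon. Among the measured compounds shown here, the one measured step, a 4.9-fold higher number from compound 1 to compound 2 (0.69 log units; beyond the scatter), went the other way: adding a group of this kind raised the number. Taking one away is therefore expected to lower it again. Compound 3 is not the same triply substituted ring as compound 1, so the return need not be exact, but compound 3 is expected to move by a 3.1-fold lower number from compound 2 to compound 3 (0.49 log units; beyond the scatter). The estimate for compound 3 in this assay is 25000 nM, with a range from 8000 nM to 80000 nM.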

Compound 3, half-maximal inhibitory concentration: 86000 nM
For compound 3 the middle estimate is 3.4-fold (0.54 log units) below the measured one; the whole stated range lies below it.
By their numbers in this assay, from the lowest: compound 1; then compounds 2 and 3 (each within the scatter of the next).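

In this assay, swapping the group of 5 heavy atoms for a hydrogen atom at this carbon, which is para to one such group and meta to two others, gives a 1.1-fold higher number from compound 2 to compound 3 (0.04 log units; within the scatter). Within this pair, then, the assay detects no difference from losing the group at this position, whereas adding a group of the same kind at another ring carbon gave a 4.9-fold higher number from compound 1 to compound 2 (0.69 log units; beyond the scatter). The effect of this group therefore depends on where it sits, and simply counting such groups would not predict the result, though nothing available explains this difference between positions.

As far as these compounds go, it remains open whether this carbon would be just as indifferent to a different substituent, such as a carboxylic acid or an amine. It is also unclear whether the same swap would leave the number unchanged on a core carrying the groups in another arrangement.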